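Swapping the aryl group on a triazole-bearing chromene ester

A few compounds are considered here, and "the series" means these few. Any claim that something is new, unique, unknown or untested is made for them only; others in the source may bear on it.

Among the compounds with values here, compound 1 `CCOC(=O)C1=Cc2ccccc2OC1(OCc1cn(-c2ccc(C)cc2)nn1)C(F)(F)F` is the only member of this small set with a measured number: in a functional assay on HeLa cells (Homo sapiens) for inhibition, read by MTT assay, with a stated time of 24 h (a lower number here means a stronger inhibitor, a higher number a weaker inhibitor), compound 1 gives 25100 nM. Compound 2 `O=C(O)C1=Cc2ccccc2OC1(OCc1cc(-c2ccc(F)cc2F)no1)C(F)(F)F` carries a free carboxylic acid instead of the ethyl ester and a different five-membered ring bearing a difluorophenyl group. In this assay compound 2 gives > 150000 nM, which is a limit of the assay rather than a number. That reading sits at the limit of > 150000 nM in this assay, at which 1 of the 2 values shown sits, so it offers no second point for comparison.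

Compound 3 `CCOC(=O)C1=Cc2ccccc2OC1(OCc1cn(-c2ccc(F)c(Cl)c2)nn1)C(F)(F)F` keeps the core and ester of compound 1 and differs only at the aromatic ring attached to the triazole: 3-chloro-4-fluorophenyl in place of 4-methylphenyl on an aromatic nitrogen. Within the data shown here, with no measured step of this kind to draw on, the change from compound 1 to compound 3 is expected to stay within the usual scatter, or to shift potency only modestly, as a 1.3-fold lower number from compound 1 to compound 3 (0.10 log units; within the scatter). Compound 3 is therefore estimated at 20000 nM, within a range from 6000 nM to 70000 nM.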

Compound 3, half-maximal inhibitory concentration: 22700 nM
For compound 3 the middle estimate is 1.1-fold (0.05 log units) below the measured one, within the range that was stated.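

Within the data shown here, this is the first measured step at this position, on an aromatic nitrogen of a five-membered aromatic ring with 3 nitrogen. In this assay, placing 3-chloro-4-fluorophenyl there in place of 4-methylphenyl gives a 1.1-fold lower number from compound 1 to compound 3 (0.04 log units; within the scatter), so these two substituted phenyl groups cannot be told apart by this read-out. Nothing measured in this set explains why the two groups read alike.

From the compounds shown here alone, both groups are substituted phenyl rings, so it remains open how a group without an aromatic ring, such as an amine or a longer carbon chain, would read at this nitrogen. Going by these compounds, the role of the ethyl ester also remains open, since compound 2 differs from compound 1 in more than one place and its reading is only a limit.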